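A few compounds are considered here, and "the series" means these few. Any claim that something is new, unique, unknown or untested is made for them only; others in the source may bear on it.

Measured so far:
compound 1 `COc1ccccc1N1CCN(C(=O)C2(C)CCc3c(C)c(O)c(C)c(C)c3O2)CC1` — in a functional assay (brain) for inhibition, with Rattus norvegicus as the target (a higher number here means a weaker inhibitor, a lower number a stronger inhibitor), compound 1 gives 15000 nM
compound 2 `Cc1c(C)c2c(c(C)c1O)CCC(C)(C(=O)N1CCN(c3ccccn3)CC1)O2` — compound 2 gives 1000 nM

Compound 2 stands at the lowest of the two numbers; the nearest is compound 1, and the step of a 15-fold lower number from compound 1 to compound 2 (1.18 log units; beyond the scatter) lies beyond the scatter. Compound 3 `Cc1c(C)c2c(c(C)c1O)CCC(C)(C(=O)N1CCN(c3ccc(Cl)cc3)CC1)O2` carries the change (4-chlorophenyl in place of pyridin-2-yl on an amine nitrogen in a ring). Going by the values given here, only that one measured step bears on it, and it concerns a different aryl group, so it fixes the size only loosely. Losing the pyridin-2-yl group is expected to cost compound 3 some potency, an estimated step of a 4.0-fold higher number from compound 2 to compound 3 (0.60 log units; beyond the scatter). Compound 3 is estimated at 4000 nM, with a range from 1000 nM to 15000 nM.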

Compound 3, half-maximal inhibitory concentration: 800 nM
For compound 3 the middle estimate is 5.0-fold (0.70 log units) above the measured one, and the stated range ends above it.
By their numbers in this assay, from the lowest: compounds 3 and 2 (each within the scatter of the next); then compound 1.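

On the amine nitrogen in a ring, this assay does not separate 4-chlorophenyl from pyridin-2-yl, with a 1.3-fold lower number from compound 2 to compound 3 (0.10 log units; within the scatter) as the step, so the ring hetero atom and hydrogen-bond acceptor of pyridin-2-yl are not needed to hold this level. The large step seen earlier is therefore not specific to pyridin-2-yl, and 2-methoxyphenyl stays apart from both other aryl groups, with a 19-fold lower number from compound 1 to compound 3 (1.27 log units; beyond the scatter) as the step. Nothing available explains this difference.

As far as these compounds go, it remains open whether an unsubstituted phenyl or a 4-methoxyphenyl group on the same nitrogen would fall with compound 2 and compound 3 or with compound 1.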